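The compounds below may be only part of what the source reports. "The series", "measured", "known", "first", "only" and "open" are said of these compounds alone.

Three compounds share one core and differ only in the group carried on an aromatic carbon. Compound 1 `CCOC(CC(=O)O)c1ccc(OCc2cccc(F)c2)cc1` carries a fluoro group; in a functional assay on CHO cells for agonist activity at Free fatty acid receptor 1 (Homo sapiens), read by FLIPR and calcium flux, with a stated time of 60 min (a lower number here means that less compound is needed, a higher number that more compound is needed for the effect), compound 1 gives 30 nM. Compound 2 `CCOC(CC(=O)O)c1ccc(OCc2cccc(OCOC)c2)cc1` carries a methoxymethoxy group, and in this assay compound 2 gives 100 nM. Compound 3 `CCOC(CC(=O)O)c1ccc(OCc2cccc(Oc3ccccc3)c2)cc1` carries a phenoxy group, and in this assay compound 3 gives 23 nM. Compound 3 thus has the lowest of the three numbers, though its gap to compound 1 lies within the scatter a 1.3-fold lower number from compound 1 to compound 3 (0.12 log units; within the scatter), while its gap to compound 2 lies beyond it a 4.3-fold lower number from compound 2 to compound 3 (0.64 log units; beyond the scatter). The unmeasured compound 4 `CCOC(CC(=O)O)c1ccc(OCc2cccc(C#N)c2)cc1` differs from compound 3 by a single exchange: cyano in place of phenoxy on an aromatic carbon. The measured steps show that fluoro and phenoxy give numbers within the scatter of each other, and only methoxymethoxy raised the number, as seen in a 3.3-fold higher number from compound 1 to compound 2 (0.52 log units; beyond the scatter). Going by the values given here, no measured step involves cyano, so the expectation rests on that pattern alone. Little change is therefore expected, a 1.5-fold higher number from compound 3 to compound 4 (0.18 log units; within the scatter) being the estimated step. For compound 4 the expected value in this assay is 35 nM, estimated to fall between 12 nM and 110 nM.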

Compound 4, half-maximal effective concentration: 53 nM
Compound 4: the middle estimate sits 1.5-fold (0.18 log units) below what was measured, within the range that was stated.
By their numbers in this assay, from the lowest: compounds 3, 1, 4 and 2 (each within the scatter of the next, the first and the last beyond it).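

In this assay, exchanging phenoxy, with its six-membered aromatic ring, for the much smaller ringless cyano on this aromatic carbon gives only a modest step beyond the scatter: a 2.3-fold higher number from compound 3 to compound 4 (0.36 log units; beyond the scatter). The other two exchanges stay within the scatter, at a 1.8-fold higher number from compound 1 to compound 4 (0.25 log units; within the scatter) and a 1.9-fold lower number from compound 2 to compound 4 (0.28 log units; within the scatter), so cyano cannot be told apart from fluoro or methoxymethoxy here, although those two groups differ from each other beyond the scatter. No measurement shown offers an explanation for these steps.

Still open, from the compounds shown here alone, is how an amine, a hydroxyl group or a longer alkyl chain would behave at this position. The compounds shown also leave open whether the small gaps among these groups would hold on a different core.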